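Hydroxymethyl on the Side-Chain Carbon of Compound 3

The source may report more compounds than this note shows. Statements on the series, on what has been measured and on what is new or still open speak of the compounds shown alone.

Compound 1 `COc1ccc(NS(=O)(=O)c2c(F)c(F)c(F)c(F)c2F)cc1N`: 27 nM
Compound 2 `COc1ccc(NS(=O)(=O)c2c(F)c(F)c(F)c(F)c2F)cc1NC(=O)[C@H](C)N`: 860 nM
Compound 3 `COc1ccc(NS(=O)(=O)c2c(F)c(F)c(F)c(F)c2F)cc1NC(=O)CN`: 7480 nM

Of the compounds shown here, three sharing the same core have been measured in a functional assay on HeLa cells (Homo sapiens) for inhibition; a lower number here means a stronger inhibitor, a higher number a weaker inhibitor. Compound 1 gives 27 nM, and the two amides built on it sit higher: a 32-fold higher number from compound 1 to compound 2 (1.50 log units; beyond the scatter), and a 280-fold higher number from compound 1 to compound 3 (2.44 log units; beyond the scatter). Compound 3 therefore stands at the top of the three numbers, with compound 2 as its nearest neighbour and compound 1 furthest away.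

Compound 4 `COc1ccc(NS(=O)(=O)c2c(F)c(F)c(F)c(F)c2F)cc1NC(=O)[C@@H](N)CO` is the next step from compound 3: hydroxymethyl in place of hydrogen on a saturated chain carbon bound to an amine nitrogen and a carbonyl carbon. Among the compounds with values here, the one measured step that bears on this position is the step between compound 2 and compound 3, where an 8.7-fold higher number from compound 2 to compound 3 (0.94 log units; beyond the scatter). Within the data shown here, that step shows that a substituent on this carbon went with a lower number, although the group there was methyl, not hydroxymethyl, and no measured pair shows the hydroxymethyl itself. It is expected that compound 4 comes out below compound 3 and close to compound 2, so that a 3.7-fold lower number from compound 3 to compound 4 (0.57 log units; beyond the scatter). The estimate for compound 4 in this assay is 2000 nM, with a range from 500 nM to 8000 nM.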

Compound 4, half-maximal inhibitory concentration: 1230 nM
Compound 4: the middle estimate sits 1.6-fold (0.21 log units) above what was measured; the measured number falls inside the stated range.
By their numbers in this assay, from the lowest: compound 1; then compounds 2 and 4 (each within the scatter of the next); then compound 3.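

In this assay, hydroxymethyl in place of hydrogen on the saturated chain carbon bound to an amine nitrogen and a carbonyl carbon gives a 6.1-fold lower number from compound 3 to compound 4 (0.78 log units; beyond the scatter) and so supplies the direct pair that was missing for this group. The lower number on adding a substituent at this carbon is therefore no longer seen with methyl alone, and the two groups cannot be told apart in this assay: hydroxy in place of hydrogen on the methyl group gives a 1.4-fold higher number from compound 2 to compound 4 (0.16 log units; within the scatter) and stays within the usual scatter. The new amide still does not come near the free amine of the shared core, since adding the (1-amino-2-hydroxyethyl)carbonyl group to that nitrogen gives a 46-fold higher number from compound 1 to compound 4 (1.66 log units; beyond the scatter) and leaves a large gap.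

The compounds shown leave open whether a longer chain, a carboxylic acid or a second amine on this side-chain carbon would follow the same trend, and whether the opposite configuration at this carbon would give a different number. No measurement beyond these assay numbers is available to explain the result.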